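The source may report more compounds than this note shows. Statements on the series, on what has been measured and on what is new or still open speak of the compounds shown alone.

Measured compounds:
compound 1, `CCCCSC(=S)C1=C(Nc2ccc(Cl)cc2)CC(C)(C)CC1=O`: in a functional assay on PBMC cells (Homo sapiens) for inhibition, read by thymidine incorporation, with a stated time of 72 h (a higher number here means a weaker inhibitor, a lower number a stronger inhibitor), compound 1 gives > 50 ug/mL, which is a limit of this assay and not a number.
compound 2, `CC1(C)CC(=O)C(C(=S)SCc2ccccc2)=C(Nc2ccc(Cl)cc2)C1`: in this assay compound 2 gives > 50 ug/mL, again a limit of this assay and not a number.

Compound 2 thus stands at the limit of this assay, and there is no number for it; both values shown sit at that limit, as recorded in the limit of > 50 ug/mL in this assay, at which 2 of the 2 values shown sit. Among the measured compounds shown here, the one step between measured compounds, a step that the two limits leave unreadable from compound 1 to compound 2, cannot be read from two limits, so its size is unknown.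

Compound 3, `CC1(C)CC(=O)C(C(=S)SCc2ccccc2)=C(Nc2ccc(Br)cc2)C1`, is the next compound to be measured in this assay. It differs from compound 2 in one place: bromo in place of chloro on an aromatic carbon. For the measured compounds named here, no measured step concerns this change; the only step recorded, from propyl to phenyl on a sulfur-bound chain carbon, gives no readable size, so nothing points either way for the halogen change.

The expectation is therefore that compound 3 stays where compound 2 stands, with no step beyond the scatter, that is a step that the limit leaves unreadable from compound 2 to compound 3 as an estimate. Compound 3 is expected to give about 60 ug/mL in this assay, within a range of 25 ug/mL to 150 ug/mL, most likely reported again as a limit.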

Compound 3, half-maximal inhibitory concentration: > 50 ug/mL
Compound 3 gave a limit, no number (the forecaster's own chance of this, stated with the estimate: 80%); the middle value lies beyond the limit too.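

In this assay compound 3 gives > 50 ug/mL, a limit of this assay and not a number. Among the compounds shown here, compound 2 also stands at a limit, so no step from chloro to bromo can be read between compound 2 and compound 3. All values shown sit at one limit: the limit of > 50 ug/mL in this assay, at which 3 of the 3 values shown sit. The compounds shown leave open whether any change to the shared core brings a measurable inhibition in this assay.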